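Halogen exchange on two enone cores in MOLT-4 inhibition

This account rests on a few compounds, and the source may have more. Where it says the series, first, only, none or still open, it means among the compounds named here.

Measured compounds:
compound 1, `O=C1/C(=C/c2cccc(Cl)c2)Cc2ccccc21`, 50900 nM
compound 2, `O=C1/C(=C/c2cccc(Br)c2)Cc2ccccc21`, 173000 nM
compound 3, `O=C1CCCCC/C1=C\c1cccc(Cl)c1`, 88600 nM

Of the compounds shown here, three have been tested in a functional assay on MOLT-4 cells (Homo sapiens) for inhibition; a higher number here means a weaker inhibitor, a lower number a stronger inhibitor. Compound 1, with the structure `O=C1/C(=C/c2cccc(Cl)c2)Cc2ccccc21`, gives 50900 nM. Compound 2, `O=C1/C(=C/c2cccc(Br)c2)Cc2ccccc21`, differs from it by bromo in place of chloro on an aromatic carbon, and in this assay compound 2 gives 173000 nM. That change made a step of a 3.4-fold higher number from compound 1 to compound 2 (0.53 log units; beyond the scatter). Compound 3, `O=C1CCCCC/C1=C\c1cccc(Cl)c1`, rests on a different core; the difference between the two cores is not broken down here. In this assay compound 3 gives 88600 nM, and its value sits within the scatter of both compound 1 and compound 2.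

Compound 4, `O=C1CCCCC/C1=C\c1cccc(Br)c1`, has not yet been measured. It differs from compound 3 by bromo in place of chloro on an aromatic carbon. Within the data shown here, this is the same kind of change as the one from compound 1 to compound 2, though the surroundings are described slightly differently: in compound 3 the halogen sits meta to a group of 9 heavy atoms, whereas in compound 1 it sits meta to a large group. Because the earlier step was a 3.4-fold higher number from compound 1 to compound 2 (0.53 log units; beyond the scatter), compound 4 is expected to show a step of about a 2.5-fold higher number from compound 3 to compound 4 (0.39 log units; beyond the scatter) relative to compound 3. The expected value for compound 4 in this assay is therefore 220000 nM, with a range estimated from 70000 nM to 600000 nM.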

Compound 4, half-maximal inhibitory concentration: 176000 nM
Compound 4: the middle estimate sits 1.3-fold (0.10 log units) above what was measured; the measured number falls inside the stated range.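

In this assay, bromo in place of chloro on an aromatic carbon gave a 2.0-fold higher number from compound 3 to compound 4 (0.30 log units; within the scatter), so on this core the exchange cannot be told apart from the ordinary spread of repeated measurements. Set beside the step on the core of compound 1, the two results do not differ by more than the scatter allows: the same change on two cores in this assay, a 3.4-fold higher number (0.53 log units; beyond the scatter) from compound 1 to compound 2 and a 2.0-fold higher number (0.30 log units; within the scatter) from compound 3 to compound 4, 1.7-fold (0.23 log units) apart, within the scatter of two such steps. Among these compounds, this is consistent with the exchange carrying over from one core to the other in the same direction, but it does not show that the step has the same size on both cores, as only the step on the core of compound 1 lies beyond the scatter, and with a single pair on each core it says nothing about any further core.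

On these data alone, only chloro and bromo appear on the aromatic ring, so it remains open whether a fluoro, a methoxy or an amine in that place would follow the same trend on either core. Among the compounds shown here, it also remains open whether a carboxylic acid or a longer chain in that place would give a lower number than the one compound 1 shows, 50900 nM.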